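Bromophenyl isomers: from compound 3 to compound 4

This account rests on a few compounds, and the source may have more. Where it says the series, first, only, none or still open, it means among the compounds named here.

In a functional assay on A549 cells (Homo sapiens) for inhibition, read by MTT assay, with a stated time of 24 h (on this read-out lower numbers stand for stronger inhibition of growth and higher numbers for weaker inhibition of growth), compound 1 `Cn1cc(-c2nc3ccccc3n2C(=O)c2cccc(Br)c2)c2ccccc21` gives 34200 nM, compound 2 `COc1ccc2c(c1)c(-c1nc3ccccc3n1C(=O)c1ccccc1OC)cn2C` gives 11900 nM and compound 3 `COc1ccc2c(c1)c(-c1nc3ccccc3n1C(=O)c1ccccc1Br)cn2C` gives 29500 nM. Compound 3 thus lies within the scatter of compound 1 and shows weaker inhibition of growth than compound 2. Compound 4 `COc1ccc2c(c1)c(-c1nc3ccccc3n1C(=O)c1cccc(Br)c1)cn2C` differs from compound 3 as follows: 3-bromophenyl in place of 2-bromophenyl on a carbonyl carbon. Among the compounds with values here, the only measured step, a 2.5-fold higher number from compound 2 to compound 3 (0.39 log units; beyond the scatter), is a modest one and exchanges a different group, so it bears only indirectly. Compound 1 carries the same 3-bromophenyl on another core and gives 34200 nM. No change beyond the scatter is therefore expected in this assay. The expected step is a 1.1-fold lower number from compound 3 to compound 4 (0.04 log units; within the scatter). For compound 4 the estimated value is 27000 nM, with an expected range of 13000 nM to 55000 nM.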

Compound 4, concentration for 50% growth inhibition: 24800 nM
The estimate for compound 4 lay 1.1-fold (0.04 log units) above the measured number, and the stated range covers the measured number.
By their numbers in this assay, from the lowest: compound 2; then compounds 4, 3 and 1 (each within the scatter of the next).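

On the carbonyl carbon, 3-bromophenyl in place of 2-bromophenyl gives in this assay a 1.2-fold lower number from compound 3 to compound 4 (0.08 log units; within the scatter) and so leaves the number unchanged, while methoxy in place of hydrogen on an aromatic carbon gives a 1.4-fold lower number from compound 1 to compound 4 (0.14 log units; within the scatter) and also makes no clear difference. 3-Bromophenyl in place of 2-methoxyphenyl gives a 2.1-fold higher number from compound 2 to compound 4 (0.32 log units; beyond the scatter) as a modest step, so both bromophenyl isomers show weaker inhibition of growth than the 2-methoxyphenyl compound. No measurement at hand bears on a cause for these steps. Still open, from the compounds shown here alone, is whether an amine or a carboxylic acid on this phenyl ring would move the number beyond the scatter.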